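The compounds below may be only part of what the source reports. "The series", "measured", "known", "first", "only" and "open" are said of these compounds alone.

Measured so far:
compound 1 `Oc1cccc(-c2cc(-c3cccc(F)c3)cc(-c3cccc(O)c3)n2)c1` — 23800 nM
compound 2 `Oc1cccc(-c2cc(-c3cccc(OC(F)(F)F)c3)cc(-c3ccccc3O)n2)c1` — > 50000 nM

In a functional assay on DU-145 cells (Homo sapiens) for inhibition (on this read-out higher numbers stand for weaker inhibition and lower numbers for stronger inhibition), compound 1 gives 23800 nM. For compound 2 this assay reports only a limit, > 50000 nM, so compound 2 sits at the limit of > 50000 nM in this assay, at which 1 of the 2 values shown sits, and its true value is not known. Compound 3 `Oc1cccc(-c2cc(-c3cccc(OC(F)(F)F)c3)cc(-c3cccc(O)c3)n2)c1` differs from compound 2 by 3-hydroxyphenyl in place of 2-hydroxyphenyl on an aromatic carbon. Within the data shown here, no measured step covers this change, so the step from compound 2 to compound 3 is expected to run toward stronger inhibition, by a modest margin an at least 1.4-fold lower number from compound 2 to compound 3 (0.15 log units; that floor lies within the scatter). Compound 3 is estimated at 35000 nM, between 12000 nM and 90000 nM.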

Compound 3, half-maximal inhibitory concentration: > 50000 nM
Compound 3: a limit, no number; the forecaster's own chance of this, stated with the estimate: 45%; at least 1.4-fold (0.15 log units) between middle value and limit.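

With 3-hydroxyphenyl in place of 2-hydroxyphenyl, this assay still gives only a limit for compound 3, so the step between compound 2 and compound 3 cannot be read. Trifluoromethoxy in place of fluoro gives an at least 2.1-fold higher number from compound 1 to compound 3 (0.32 log units; beyond the scatter), which means weaker inhibition. Only compound 1 keeps a number, and the other two sit together: the limit of > 50000 nM in this assay, at which 2 of the 3 values shown sit.

As far as these compounds go, the true values of compound 2 and compound 3 remain unknown. Also open, from the compounds shown here alone, is how an amine or a carboxylic acid in place of the fluoro would compare with compound 1.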